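The source may hold more compounds than are shown below. What is called first, only, known or untested is meant among the compounds shown, and "the series" means these compounds.

Measured compounds:
Compound 1, `CC1CCN(c2c(S(=O)(=O)c3cc(F)cc(F)c3)cnc3c(F)cccc23)CC1`: 9%
Compound 2, `COc1ccc2ncc(S(=O)(=O)c3cc(F)cc(F)c3)c(N3CCC(C)CC3)c2c1`: 30%

Both numbers come from an assay on isolated protein for displacement of a labelled ligand from metabotropic glutamate receptor 5 (Homo sapiens), with a stated time of 60 min, tested at 1 uM; on this read-out lower numbers stand for less inhibition and higher numbers for more inhibition at the one concentration tested (going by the name of the read-out). Of the two compounds measured, compound 1 stands lowest. Among the compounds with values here, compound 2 lies above it by more than the usual scatter of repeated measurements, so the two compounds are genuinely apart, but they differ from each other in more than one place, and no single structural step between measured compounds has been isolated.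

Compound 3, `CC1CCN(c2c(S(=O)(=O)c3ccc(Cl)c(Cl)c3)cnc3c(F)cccc23)CC1`, has not yet been measured in this assay. It differs from compound 1 in one place:

3,4-dichlorophenyl in place of 3,5-difluorophenyl on a sulfonyl sulfur

Within the data shown here, nothing among the measured compounds shows what such an exchange on the sulfonyl sulfur does, so the expectation rests on compound 1 alone and carries a wide margin. The step from compound 1 to compound 3 is expected to be a number 11 percentage points higher from compound 1 to compound 3 (beyond the scatter), a small rise that may well stay within the usual scatter. Compound 3 is therefore expected to give about 20% in this assay, most likely somewhere between 3% and 45%.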

Compound 3, a percentage reported as inhibition, at one concentration (the size of the read-out at that concentration, not a potency): 95%
Compound 3: the middle estimate sits 75 percentage points below what was measured, and the stated range ends below it.
By their numbers in this assay, from the lowest: compound 1; then compound 2; then compound 3.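

In this assay, the group on the sulfonyl sulfur proves to be a highly sensitive place in the molecule: with the rest of the structure unchanged, 3,4-dichlorophenyl in place of 3,5-difluorophenyl gives a number 86 percentage points higher from compound 1 to compound 3 (beyond the scatter). The two groups match in everything counted here, each with 8 heavy atoms, one six-membered aromatic ring of carbon only and no hydrogen-bond donors or acceptors, so the change lies in which halogen the ring carries and in the positions given by the two names. No measurement shown offers an explanation for the size of this step.

From the compounds shown here alone, this single exchange changes the halogen and the ring positions together, so the contribution of each remains open; 3,5-dichlorophenyl and 3,4-difluorophenyl on the same sulfur would pull the two apart, and plain phenyl would show what the halogens add at all. Going by these compounds, it also remains open whether 3,4-dichlorophenyl brings a similar rise on the core of compound 2, and the result, taken at a single concentration, gives no potency for compound 3.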